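The source may report more compounds than this note shows. Statements on the series, on what has been measured and on what is new or still open speak of the compounds shown alone.

Measured in a functional assay on KB cells (Homo sapiens) for inhibition, read by MTT assay, with a stated time of 24 h, tested at 1 ug/mL; on this read-out higher numbers stand for more inhibition of growth at the one concentration tested and lower numbers for less inhibition of growth:
- compound 1 `O=C(CCCCC(S)CCS)NO`: 10.6%
- compound 2 `O=C(CCCCC1CCSS1)Nc1cccc(C(F)(F)F)c1`: 9.5%

Compound 2, at 9.5%, stands level with compound 1, at 10.6%, as the two values lie within the usual scatter of each other. The two compounds differ in more than one place, so the series offers no measured single change to use as a guide.

Next is compound 3 `O=C(CCCCC1CCSS1)Nc1ccc([N+](=O)[O-])c(C(F)(F)F)c1`, which differs from compound 2 by nitro in place of hydrogen on an aromatic carbon. The nitro sits ortho to a trifluoromethyl group and para to a large group.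

For the measured compounds named here, with no precedent for this change in this assay, the expectation rests only on compound 2 at 9.5%. The estimated change is a number 3.5 percentage points higher from compound 2 to compound 3 (within the scatter), a slight rise that is not expected to clear the scatter. For compound 3 the estimated value is 13%, with an expected range from 3% to 32%.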

Compound 3, percent growth inhibition at one concentration: "not active" (no number reported)
Compound 3 has no reported number here; there is nothing to compare the estimate with.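

Compound 3 carries only a "not active" note and no number in this assay, so no step can be read from compound 2 to compound 3. No available evidence bears on this result. Left open is how far nitro in place of hydrogen on the aromatic carbon moves the read-out in this assay, if at all.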